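A few compounds are considered here, and "the series" means these few. Any claim that something is new, unique, unknown or untested is made for them only; others in the source may bear on it.

Three compounds have entries so far in a functional assay on SiHa cells (Homo sapiens) for inhibition, read by MTT assay; on this read-out higher numbers stand for weaker inhibition and lower numbers for stronger inhibition. Among the compounds with values here, compound 2 `CC1(C)C2CCC1(C)C(OC(=O)/C=C/c1cc(O)c(O)c(Br)c1)C2` is the only one with a number, at 29000 nM. Compound 1 `O=C(/C=C/c1cc(O)c(O)c([N+](=O)[O-])c1)OCCc1ccccc1` has the entry "not determined" (no result reported). Compound 3 `O=C(/C=C/c1cc(O)c(O)c(Cl)c1)OCCc1ccccc1` has the entry "not determined" (no result reported), so it has no single number of its own and stands with compound 1 as one of two entries without a result.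

The next compound is compound 4 `O=C(/C=C/c1cc(O)c(O)c(Br)c1)OCCc1ccccc1`, which is still to be measured in this assay. The structural change from compound 3 is bromo in place of chloro on an aromatic carbon, with bromo in place of chloro on an aromatic carbon, ortho to a hydroxy group. No measured step connects any two of these compounds, so the data cannot size this change directly. The expectation is a step no larger than the usual scatter, in neither direction, although the missing result for compound 3 leaves this untested. The nearest guide is compound 2 at 29000 nM, which carries the same bromo but differs from compound 4 elsewhere in its structure. Compound 4 is expected at about 20000 nM, with an estimated range from 7000 nM to 55000 nM.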

Compound 4, half-maximal inhibitory concentration: 28500 nM
Estimate against measurement, compound 4: 1.4-fold (0.15 log units) below; the measured number falls inside the stated range.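

In this assay, within the data shown here, compound 4 gives 28500 nM, but compound 3 has no single number there, so no step between compound 3 and compound 4 can be read. The compounds shown leave open how bromo and chloro compare at this position on the ring. No other data available here bear on this result.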